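The compounds below may be only part of what the source reports. "The series", "measured", "known", "first", "only" and "open" are said of these compounds alone.

Measured compounds:
Compound 1, `O=C(O)CCN1Cc2ccc(NC(=O)c3ccc(N4CCNCC4)cc3)cc2C1=O`, with 540 nM.
Compound 2, `O=C(O)CCN1Cc2ccc(NC(=O)c3ccc4c(c3)CNCC4)cc2C1=O`, with 1100 nM.
Compound 3, `CC(CC(=O)O)N1Cc2ccc(NC(=O)c3ccc(N4CCNCC4)cc3)cc2C1=O`, with 3740 nM.

All three were tested in a functional assay on a cell-free system (Platelet, plasma, Homo sapiens) for inhibition; a lower number here means a stronger inhibitor, a higher number a weaker inhibitor. Within the data shown here, compound 1 and compound 2 carry different cores; the difference between the two cores is not broken down here, and their two values show only that compound 2 gives the higher number of the pair. Compound 1 and compound 3 share a core and differ in one place, (methyl in place of hydrogen on a saturated chain carbon bound to an amide-type nitrogen in a ring and a saturated chain carbon). That change gave a 6.9-fold higher number from compound 1 to compound 3 (0.84 log units; beyond the scatter).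

Compound 4, `CC(CC(=O)O)N1Cc2ccc(NC(=O)c3ccc4c(c3)CNCC4)cc2C1=O`, has not yet been measured in this assay. It stands to compound 2 as compound 3 stands to compound 1: the difference is methyl in place of hydrogen on a saturated chain carbon bound to an amide-type nitrogen in a ring and a saturated chain carbon, the same change at the same place, this time made on the core of compound 2. Among the measured compounds shown here, the step of a 6.9-fold higher number from compound 1 to compound 3 (0.84 log units; beyond the scatter) is the only observation of this change, so the expectation for compound 4 rests on it alone, and a single measured pair gives no way to tell whether the core alters the outcome. Compound 4 is therefore expected to come out as a weaker inhibitor than its parent by about the size already seen. The estimated step, a 6.8-fold higher number from compound 2 to compound 4 (0.83 log units; beyond the scatter), is set beside the earlier one. For compound 4 in this assay the estimate is 7500 nM, with a range from 3000 nM to 19000 nM. A number that high could also come back only as a limit.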

Compound 4, half-maximal inhibitory concentration: 86 nM
Compound 4: middle estimate off by 87-fold (1.94 log units), on the high side, outside the stated range (below it).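

In this assay, the change from 2-carboxyethyl to 1-(carboxymethyl)ethyl gave a 13-fold lower number from compound 2 to compound 4 (1.11 log units; beyond the scatter), so the methyl that weakened inhibition on one core strengthened it on the other. In this series, then, the outcome of the change did not carry from one core to the other, in direction or in size: the same change on two cores in this assay, a 6.9-fold higher number (0.84 log units; beyond the scatter) from compound 1 to compound 3 and a 13-fold lower number (1.11 log units; beyond the scatter) from compound 2 to compound 4, 89-fold (1.95 log units) apart, beyond the scatter of two such steps

What the two pairs do not show is which feature of the cores reverses the outcome, or which way the same methyl would go on a third core; they establish that the core matters for this change, but they give no rule for predicting it.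

The compounds shown leave open whether an ethyl in place of this methyl, on the same saturated chain carbon, would split between the two cores in the same way. As far as these compounds go, they also leave open whether the split would persist with a tetrazole or a methyl ester in place of the carboxylic acid, so how far the reversal extends beyond these four compounds remains unknown.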